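The source may report more compounds than this note shows. Statements on the series, on what has been measured and on what is new or still open speak of the compounds shown alone.

In a functional assay on MT4 cells (Homo sapiens) for antiproliferative activity, read by MTT assay, with a stated time of 96 h (a higher number here means a weaker inhibitor, a lower number a stronger inhibitor), compound 1 `O=C1C2=C(C(=O)c3ncccc31)C1(CS2)NC(=O)N(c2ccc(Cl)cc2)C1=O` gives 10 nM and compound 2 `CCN(CC)c1ccc(N2C(=O)NC3(CSC4=C3C(=O)c3ncccc3C4=O)C2=O)cc1`, which carries diethylamino in place of chloro on an aromatic carbon, gives 8 nM. Compound 1 thus stands level with compound 2, and both numbers are far smaller than that of compound 3 `O=C1NNC(=O)C2(CSC3=C2C(=O)c2ncccc2C3=O)N1`, at 550 nM; 500 nM; 550 nM (3 entries).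

Compound 4 `O=C1C2=C(C(=O)c3ncccc31)C1(CS2)NC(=O)N(c2ccncc2)C1=O` keeps the core of compound 1 but has pyridin-4-yl in place of 4-chlorophenyl on an amide-type nitrogen in a ring. For the measured compounds named here, one measured step bears on this change. It altered a group on that same aromatic ring and came to a 1.3-fold lower number from compound 1 to compound 2 (0.10 log units; within the scatter), so that swap left the number within the scatter. Going by the values given here, no measured step replaces the ring itself, which leaves the new change less well covered. A small rise in the number is therefore expected, estimated as a 2.0-fold higher number from compound 1 to compound 4 (0.30 log units; within the scatter). Compound 4 is expected at about 20 nM, with an estimated range of 7 nM to 70 nM.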

Compound 4, half-maximal inhibitory concentration: 3 nM
Compound 4: middle estimate off by 6.7-fold (0.82 log units), on the high side, outside the stated range (below it).
By their numbers in this assay, from the lowest: compound 4; then compounds 2 and 1 (each within the scatter of the next).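

On the amide-type nitrogen in a ring, the aromatic ring itself can be changed and the number still falls: in this assay, pyridin-4-yl in place of 4-chlorophenyl gives a 3.3-fold lower number from compound 1 to compound 4 (0.52 log units; beyond the scatter). For the compounds shown here, the earlier swap at this position altered only a group on the ring and gave a 1.3-fold lower number from compound 1 to compound 2 (0.10 log units; within the scatter), so this is the first change here to go beyond the scatter, although only modestly. Repeat readings in this assay lie close together, which supports treating this modest step as real: the several entries of compound 3 in this assay, 550 nM; 500 nM; 550 nM (3 entries)

Compound 4 loses the chloro group and gains a ring nitrogen in a single change, so the two effects remain tangled, and a plain phenyl group at this position would be needed to separate them. As far as these compounds go, whether the place of the ring nitrogen matters also stays open, a question that pyridin-3-yl or pyridin-2-yl would address.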